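A few compounds are considered here, and "the series" means these few. Any claim that something is new, unique, unknown or untested is made for them only; others in the source may bear on it.

Compound 1 `O=C(CCCCNC(=O)C(O)(O)C(F)(F)F)Nc1ccccc1` gives 20300 nM as a measured number
Compound 2 `O=C(CCCCNC(=O)c1cc(=O)c(O)co1)Nc1ccccc1` gives > 100000 nM as a limit
Compound 3 `NC(=O)C(=O)NCCCCC(=O)Nc1ccccc1` gives > 100000 nM as a limit

In a functional assay on HCT-116 cells (Homo sapiens) for inhibition, read by colorimetric assay, with a stated time of 3 days (a lower number here means a stronger inhibitor, a higher number a weaker inhibitor), compound 3 stands at > 100000 nM as a limit of the assay, not a number. Compound 2 likewise reports only the limit > 100000 nM and no number. Only compound 1 gives a true number, 20300 nM in this series.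

Compound 4 `C/C(=N\O)C(=O)NCCCCC(=O)Nc1ccccc1` loses the carbamoyl of compound 3 and takes a new group on the same carbonyl carbon, whose other neighbour is an amide-type nitrogen: a group of 4 heavy atoms (2 carbon, 1 nitrogen, 1 oxygen; no ring) in place of a group of 3 heavy atoms (1 carbon, 1 nitrogen, 1 oxygen; no ring), on a carbonyl carbon is the whole change.

Two measured steps replace the group at this place and both weaken the compounds: an at least 4.9-fold higher number from compound 1 to compound 2 (0.69 log units; beyond the scatter) and an at least 4.9-fold higher number from compound 1 to compound 3 (0.69 log units; beyond the scatter) each end at the limit. There is also a step that the two limits leave unreadable from compound 2 to compound 3 and so it offers no guide.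

Compound 4 also lacks the 2,2,2-trifluoro-1,1-dihydroxyethyl group of compound 1, so the expectation follows the limit of > 100000 nM in this assay, at which 2 of the 3 values shown sit, with no step beyond the scatter. The expected step is a number no higher from compound 3 to compound 4 (the limit leaves the size open) in this assay by this estimate. Compound 4 is estimated at 100000 nM within an expected range of 35000 nM to 300000 nM and may well return only a limit.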

Compound 4, half-maximal inhibitory concentration: > 100000 nM
Compound 4: a limit, no number; the forecaster's own chance of this, stated with the estimate: 70%; the middle value sits exactly at the limit.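

In this assay, a third replacement of the 2,2,2-trifluoro-1,1-dihydroxyethyl group on this carbonyl carbon also ends at a limit, this time with a group that has no ring and only one more heavy atom than carbamoyl, and it gives an at least 4.9-fold higher number from compound 1 to compound 4 (0.69 log units; beyond the scatter). The steps from compound 2 to compound 4 and from compound 3 to compound 4 cannot be read, as both ends of each are limits, so these three compounds cannot be ranked. Compound 1 remains the only one with a true number, and none of the compounds shown goes against this picture: the limit of > 100000 nM in this assay, at which 3 of the 4 values shown sit.

Going by these compounds, whether a carboxylic acid or a hydroxamic acid on this carbonyl carbon would give a measured number stays open. So does whether a longer chain would change the number of compound 1.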